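Compound 4 Against a Level Set of Benzyl Amides

The compounds below may be only part of what the source reports. "The series", "measured", "known", "first", "only" and "open" are said of these compounds alone.

In a functional assay on A2780 cells (Homo sapiens) for antiproliferative activity, read by resazurin assay, with a stated time of 72 h (a higher number here means a weaker inhibitor, a lower number a stronger inhibitor), compound 3 (`CCOc1ccc(CN(C)C(=O)c2cc3c(Cc4ccccc4)n[nH]c3cc2O)cc1`) gives 3200 nM and stands within the scatter of the other two measured compounds. Compound 1 (`CN(Cc1cccc(F)c1)C(=O)c1cc2c(Cc3ccccc3)n[nH]c2cc1O`) stands at 5000 nM and compound 2 (`CN(Cc1ccc(F)cc1)C(=O)c1cc2c(Cc3ccccc3)n[nH]c2cc1O`) at 4100 nM there. Compound 4 (`COc1cc(CN(C)C(=O)c2cc3c(Cc4ccccc4)n[nH]c3cc2O)ccc1Cl`) has 4-chloro-3-methoxyphenyl in place of 4-ethoxyphenyl on a saturated chain carbon bound to an amide-type nitrogen. For the measured compounds named here, three measured steps bear on it: a 1.2-fold lower number from compound 1 to compound 2 (0.09 log units; within the scatter) and a 1.6-fold lower number from compound 1 to compound 3 (0.19 log units; within the scatter) and a 1.3-fold lower number from compound 2 to compound 3 (0.11 log units; within the scatter) are all within the scatter. Going by the values given here, no measured compound carries a chloro or methoxy group. In this assay no step beyond the scatter is expected, and the estimated one (a 1.1-fold higher number from compound 3 to compound 4 (0.04 log units; within the scatter)) stays inside it. Compound 4 is expected at 3500 nM (estimated range 1500 nM to 8000 nM).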

Compound 4, half-maximal inhibitory concentration: 4100 nM
For compound 4 the middle estimate is 1.2-fold (0.07 log units) below the measured one; the range from low to high includes it.
By their numbers in this assay, from the lowest: compounds 3, 2, 4 and 1 (each within the scatter of the next).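

In this assay, for the compounds shown here, 4-chloro-3-methoxyphenyl, the first group here to bring in chlorine and to carry two substituents on its ring, stays within the scatter of all three earlier groups (a 1.3-fold higher number from compound 3 to compound 4 (0.11 log units; within the scatter); no change at the digits printed from compound 2 to compound 4 (within the scatter); a 1.2-fold lower number from compound 1 to compound 4 (0.09 log units; within the scatter)). This place on a saturated chain carbon bound to an amide-type nitrogen therefore tolerates this larger change of ring substitution without a step beyond the scatter, so all four compounds remain level. From the compounds shown here alone, whether an amine or a carboxylic acid at this place would leave the number equally level stays open. Nothing available gives a reason for this level picture.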